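Aryl variation on the shared core: working notes

The source may report more compounds than this note shows. Statements on the series, on what has been measured and on what is new or still open speak of the compounds shown alone.

Measured so far:
compound 1 `N#CC1=C(N)OC(c2c[nH]c3ccccc23)=C(C#N)C1c1ccccc1F`: "not active" (no number reported)
compound 2 `CN(C)c1ccc(C2C(C#N)=C(N)OC(c3c[nH]c4ccccc34)=C2C#N)cc1`: 14.4%

Among the compounds with values here, in a functional assay, tested at 50 ug/mL (a lower number here means a weaker effect, a higher number a stronger effect of the compound at the concentration tested), compound 2 gives 14.4%, the only number in the set. Compound 1 gives "not active" (no number reported), with no number reported. No step between measured compounds is shown, so nothing within the set says how much one change at the saturated ring carbon moves the read-out.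

Compound 3 `Cc1ccccc1C1C(C#N)=C(N)OC(c2c[nH]c3ccccc23)=C1C#N` differs from compound 2 in one place: 2-methylphenyl in place of 4-(dimethylamino)phenyl on a saturated ring carbon. The substituent that enters carries no hydrogen-bond acceptor, unlike the one that leaves. The reading of compound 2 in this assay is modest, and the only other entry, compound 1, returned no number, so the new compound is expected to stay in the low range. A downward step, of about the size of the usual scatter, is expected: a number 6.4 percentage points lower from compound 2 to compound 3 (within the scatter). Compound 3 is estimated at 8%, within a range from 0% to 20%.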

Compound 3, a percentage reported as activity, at one concentration (the size of the read-out at that concentration, not a potency): 10.4%
Estimate against measurement, compound 3: 2.4 percentage points below; low and high end bracket the measured number.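

In this assay, within the data shown here, the exchange of 4-(dimethylamino)phenyl for 2-methylphenyl on the saturated ring carbon gives a number 4 percentage points lower from compound 2 to compound 3 (within the scatter) and provides the first readable step at this position. Both compounds keep a measurable read-out, so an aryl group without a hydrogen-bond acceptor can occupy this position with no change beyond the scatter. The step says nothing about compound 1, which gives "not active" (no number reported) and so offers no number for comparison. No measured evidence accounts for the size of this step.

From the compounds shown here alone, it remains open whether a carboxylic acid or a primary amine on the phenyl ring would move the read-out beyond the scatter. The effect of a longer alkyl chain in place of the aryl group at this saturated ring carbon is also unresolved.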